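The compounds below may be only part of what the source reports. "The series", "measured", "known", "first", "only" and "open" are said of these compounds alone.

Series notes. In a functional assay on CHO cells for positive allosteric modulation of metabotropic glutamate receptor 2 (Homo sapiens), with a stated time of 30 min (a higher number here means a larger maximal response, a lower number a smaller maximal response), compound 1 `CC(C)CCn1ccc(N2CCc3ccccc3C2)c(C#N)c1=O` gives 310%, compound 2 `N#Cc1c(N2CCC(c3ccccc3)CC2)ccn(CCC2CC2)c1=O` gives 316% and compound 3 `N#Cc1c(N2CCC(c3ccc(F)cc3)CC2)ccn(CC2CC2)c1=O` gives 258%. In this assay compound 3 thus stands lowest of the three numbers, with compound 1 nearer to it and compound 2 further away, both gaps beyond the scatter. For the measured compounds named here, compound 4 `N#Cc1c(N2CCC(c3c(F)cccc3F)CC2)ccn(CC2CC2)c1=O` differs from compound 3 in one place: 2,6-difluorophenyl in place of 4-fluorophenyl on a saturated ring carbon No measured pair in the set carries this change, so nothing here anchors its size. In this assay a small step is expected, a number 4 percentage points higher from compound 3 to compound 4 (within the scatter), in either direction and probably not beyond the scatter. Compound 4 is therefore estimated at 262% in this assay, within a range from 200% to 330%.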

Compound 4, largest response reached (Emax), in percent of the reference or control that the assay uses: 291%
Compound 4: the middle estimate sits 29 percentage points below what was measured; low and high end bracket the measured number.
By their numbers in this assay, from the lowest: compound 3; then compound 4; then compounds 1 and 2 (each within the scatter of the next).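

For the compounds shown here, on the saturated ring carbon, three ring bonds from the ring nitrogen, 2,6-difluorophenyl in place of 4-fluorophenyl gives a number 33 percentage points higher from compound 3 to compound 4 (beyond the scatter) in this assay, the first single-place step. The maximal response therefore responds to the fluorine pattern on this phenyl ring, although the aromatic ring itself stays the same. Nothing available accounts for the size or direction of this step.

Open, from the compounds shown here alone, is whether a pyridine ring or a chlorophenyl group in this place would keep the higher response. Also open, going by these compounds, is whether the step holds when the group on the core's ring nitrogen is changed.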